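This account rests on a few compounds, and the source may have more. Where it says the series, first, only, none or still open, it means among the compounds named here.

Compound 1 `COc1cc2c(Oc3ccc(NC(=O)c4nccc(-c5ccc(C)cc5)n4)cc3F)ccnc2cc1OCCCN1CCCCC1`: 620 nM
Compound 2 `COc1cc2c(Oc3ccc(NC(=O)c4nccc(-c5ccc(F)cc5)n4)cc3F)ccnc2cc1OCCCN1CCCCC1`: 120 nM

For the measured compounds named here, in a functional assay on HT-29 cells (Homo sapiens) for cytotoxicity, read by MTT assay, with a stated time of 72 h (on this read-out higher numbers stand for weaker inhibition and lower numbers for stronger inhibition), compound 1 holds the highest of the two numbers; the only measured step, a 5.2-fold lower number from compound 1 to compound 2 (0.71 log units; beyond the scatter), concerns a fluoro in place of methyl on an aromatic carbon. Compound 3 `COc1cc2c(Oc3ccc(NC(=O)c4nccc(-c5ccc(C)cc5)n4)cc3F)ccnc2cc1OCCCN1CCN(C)CC1` differs from compound 1 at a different site: 4-methylpiperazin-1-yl in place of piperidin-1-yl on a saturated chain carbon, three bonds along the chain from an oxygen on an aromatic ring. Going by the values given here, no measured step touches this exchange, so the data give no ground for a shift beyond the scatter in either direction. Compound 3 is therefore expected to come out close to compound 1, at 620 nM with a range of 250 nM to 1600 nM, the estimated step being no change at the digits printed from compound 1 to compound 3 (within the scatter).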

Compound 3, half-maximal inhibitory concentration: 210 nM
Estimate against measurement, compound 3: 3.0-fold (0.47 log units) above; measured number outside the range, below it.
By their numbers in this assay, from the lowest: compounds 2 and 3 (each within the scatter of the next); then compound 1.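

For the compounds shown here, the end of the propyl chain, which the earlier compounds left untouched, turns out to respond in this assay: 4-methylpiperazin-1-yl in place of piperidin-1-yl gives a 3.0-fold lower number from compound 1 to compound 3 (0.47 log units; beyond the scatter). The number therefore moves with a change at this site as well as with the change on the aromatic carbon. Nothing at hand bears on the cause of this step.

From the compounds shown here alone, what morpholin-4-yl, an unsubstituted piperazin-1-yl or a longer chain would do here remains open. So does whether the same exchange would give a similar step on compound 2, which carries the fluoro group.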